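From Trifluoromethyl to Methoxy: One Exchange on the Aryl Ring

This account rests on a few compounds, and the source may have more. Where it says the series, first, only, none or still open, it means among the compounds named here.

Compound 1 `O=C1NC(=S)S/C1=C\C=C\c1ccccc1` was tested in a functional assay on DLD-1 cells (Homo sapiens), read by microscopy and crystal violet staining, with a stated time of 20 h, tested at 10 ug/mL (on this read-out higher numbers stand for more inhibition at the one concentration tested (going by the name of the read-out) and lower numbers for less inhibition), and gives 81%. Compound 2 `O=C1NC(=S)S/C1=C\C=C\c1ccccc1OCc1ccccc1C(F)(F)F` gives 80% in this assay; of the two numbers it is the lower, yet the gap to compound 1 lies within the scatter, so the two cannot be told apart. Compound 3 `COc1ccccc1COc1ccccc1/C=C/C=C1\SC(=S)NC1=O` has not been measured. It differs from compound 2 in one place: methoxy in place of trifluoromethyl on an aromatic carbon. Among the compounds with values here, no step between measured compounds is available to size this change. Compound 3 is expected to move by about a number 2 percentage points lower from compound 2 to compound 3 (within the scatter). Compound 3 is therefore estimated at 78%, within a range from 60% to 92%.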

Compound 3, a percentage reported as inhibition, at one concentration (the size of the read-out at that concentration, not a potency): 98%
Beside the measured number, compound 3's estimate is 20 percentage points below it; measured number above the stated range.
By their numbers in this assay, from the lowest: compounds 2 and 1 (each within the scatter of the next); then compound 3.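

Methoxy in place of trifluoromethyl on an aromatic carbon, ortho to a large group, brings a number 18 percentage points higher from compound 2 to compound 3 (beyond the scatter) and gives the first step that can be read at this position. Within the data shown here, it shows that inhibition at the one concentration tested depends on which group sits at this place, which the earlier compounds could not show, as they offered no step here.

Going by these compounds, whether a hydroxyl, an amine or a carboxylic acid on this carbon would give a similar number stays open. The data shown offer nothing that explains this step.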